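Cytotoxicity of a butoxy analogue of compound 1

The source may report more compounds than this note shows. Statements on the series, on what has been measured and on what is new or still open speak of the compounds shown alone.

Compound 1, with the structure `COc1cc2c(c(O)c1OC)C(=O)[C@]1(OC)C=C[C@H]2N(C(=O)OCC(C)C)N1C(=O)OCC(C)C`, was tested in an ADME assay on KB cells (Homo sapiens) for cytotoxicity; a higher number here means that more compound is needed for the effect, a lower number that less compound is needed. In this assay compound 1 reaches only the limit of the method, > 300 ug/mL, so no number is known for it. A second compound, compound 2, with the structure `CCCCOc1c(OC)c(OC)cc2c1C(=O)[C@]1(OC)C=C[C@H]2N(C(=O)OCC)N1C(=O)OCC`, carries a butoxy group and ethyl carbamates; in this assay compound 2 gives 76 ug/mL. Compound 1 thus stands at the limit, as noted in the limit of > 300 ug/mL in this assay, at which 1 of the 2 values shown sits, while compound 2 stands at a measured number.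

Compound 3, with the structure `CCCCOc1c(OC)c(OC)cc2c1C(=O)[C@]1(OC)C=C[C@H]2N(C(=O)OCC(C)C)N1C(=O)OCC(C)C`, is not yet measured. It differs from compound 1 by a single change: butyl in place of hydrogen on an oxygen on an aromatic ring. Among the compounds with values here, compound 2 and compound 3 share the butoxy group but differ in their carbamates, and no step between compound 1 and compound 2 is available.

A step downward in concentration is expected for compound 3, given that compound 2 gives 76 ug/mL in this assay. The expected step is an at least 3.0-fold lower number from compound 1 to compound 3 (0.47 log units; beyond the scatter). Compound 3 is estimated to give 100 ug/mL in this assay, within a range from 30 ug/mL to 300 ug/mL.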

Compound 3, concentration for half-maximal effect: 22.1 ug/mL
Estimate against measurement, compound 3: 4.5-fold (0.66 log units) above; measured number outside the range, below it.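

The change from hydroxy to butoxy, on an oxygen on an aromatic ring, gives an at least 13-fold lower number from compound 1 to compound 3 (1.13 log units; beyond the scatter) in this assay. Within the data shown here, this is the first reading of a single change at this position, as the earlier pair, compound 1 and compound 2, differs in more than one place and offers no step. With the carbamates held the same, the drop in the number can now be tied to this one oxygen substituent, although its size is only a lower bound, and the full step may be larger, as compound 1 stands at a limit of the method: the limit of > 300 ug/mL in this assay, at which 1 of the 3 values shown sits.

The compounds shown leave open how the number depends on the group at this oxygen, since a single butyl says nothing about whether a longer chain or an amine in its place would read the same way. Going by these compounds, whether the step carries over to the ethyl carbamates of compound 2 also remains open, and the true value of compound 1 stays unknown.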